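Chloro for trifluoromethyl on the benzyl group: compound 4

The compounds below may be only part of what the source reports. "The series", "measured", "known", "first", "only" and "open" are said of these compounds alone.

Measured compounds in an assay on Sf9 cells for inhibition of prolyl hydroxylase EGLN2 (Homo sapiens), read by TR-FRET, with stated times of 30 min and 2 h; on this read-out lower numbers stand for stronger inhibition and higher numbers for weaker inhibition:
compound 1 `O=C(O)CNC(=O)c1c(O)c2ccc(Cl)cc2n(Cc2ccc(C(F)(F)F)cc2)c1=O`, 3.2 nM
compound 2 `O=C(O)CNC(=O)c1c(O)c2c(n(Cc3ccc(C(F)(F)F)cc3)c1=O)COCC2`, 11 nM
compound 3 `O=C(O)CNC(=O)c1c(O)c2c(n(Cc3ccc(C(F)(F)F)cc3)c1=O)CCOC2`, 14 nM

Compound 3 carries the highest of the three numbers. Its nearest neighbour is compound 2, whose value lies within the scatter of that of compound 3, so no order between the two can be read. Among the compounds with values here, compound 1 sits furthest away, with a number that is lower beyond the scatter; the two compounds differ in their core, and no single step between them is set out here.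

Compound 4 `O=C(O)CNC(=O)c1c(O)c2c(n(Cc3ccc(Cl)cc3)c1=O)CCOC2` keeps the core of compound 3 and changes only the benzyl substituent: chloro in place of trifluoromethyl on an aromatic carbon, so chloro in place of trifluoromethyl on an aromatic carbon. Within the data shown here, no measured pair shows this exchange, so the size of the step is not known from the series. The expectation for the step from compound 3 to compound 4 is a small one, a 1.1-fold higher number from compound 3 to compound 4 (0.03 log units; within the scatter), not clearly beyond the scatter in either direction. Compound 4 is therefore estimated at 15 nM, with a range from 6 nM to 40 nM.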

Compound 4, half-maximal inhibitory concentration: 5.9 nM
Estimate against measurement, compound 4: 2.5-fold (0.41 log units) above; the measured number lies below the stated range.
By their numbers in this assay, from the lowest: compounds 1, 4, 2 and 3 (each within the scatter of the next, the first and the last beyond it).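

In this assay, within the data shown here, the exchange of trifluoromethyl for chloro gives a 2.4-fold lower number from compound 3 to compound 4 (0.38 log units; beyond the scatter) and is the first measured change on the benzyl group, since compounds 1, 2 and 3 all carry 4-(trifluoromethyl)phenyl. This place on the aromatic ring therefore responds to its substituent, and trifluoromethyl is not needed there for a low number on the core of compound 3. No measured property of either group accompanies this step, so the data give no explanation for it.

Open, going by these compounds, is whether the same exchange has a similar effect on the core of compound 1 or on that of compound 2. Also open, on these data alone, is how a fluoro, bromo, methoxy or nitrile group would read at this place, since one exchange sets no trend across substituents.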